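A few compounds are considered here, and "the series" means these few. Any claim that something is new, unique, unknown or untested is made for them only; others in the source may bear on it.

Working notes on a small spiro series tested in an assay on HEK293 cells for displacement of a labelled ligand from NPC1-like intracellular cholesterol transporter 1 (Homo sapiens); on this read-out higher numbers stand for weaker inhibition and lower numbers for stronger inhibition. Of the compounds shown here, two have numbers so far. Compound 1, `O=C(CN1CN(c2ccccc2)C2(CCN(C(=O)c3ccc(C4CCCCC4)cc3)CC2)C1=O)NCCCCO`, gives 10300 nM in this assay. Compound 2, `CC(C)(C)c1ccc(C(=O)N2CCC3(CC2)C(=O)N(CC(=O)NCCO)CN3c2ccccc2)cc1`, gives 1000 nM in this assay, the lowest of the two numbers; the gap to compound 1 is beyond the scatter, and since the two structures differ in more than one place, nothing more than that comparison of the two values can be drawn from them.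

The next compound, compound 3, is `CC(C)(C)OC(=O)NCCNC(=O)CN1CN(c2ccccc2)C2(CCN(C(=O)c3ccc(C(C)(C)C)cc3)CC2)C1=O`. It differs from compound 2 in one place: (tert-butoxycarbonyl)amino in place of hydroxy on a saturated chain carbon, two bonds along the chain from an amide-type nitrogen. Within the data shown here, no measured pair shows this change, so there is no step to lean on. With only compound 2 at 1000 nM as a reference, and no information on whether the (tert-butoxycarbonyl)amino group helps or hurts in this assay, the expected step is one of no clear size, taken as no change at the digits printed from compound 2 to compound 3 (within the scatter), within the scatter in either direction. For compound 3 the estimated value in this assay is 1000 nM, with a range from 300 nM to 4000 nM.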

Compound 3, half-maximal inhibitory concentration: 10900 nM
Beside the measured number, compound 3's estimate is 11-fold (1.04 log units) below it; the measured number lies above the stated range.
By their numbers in this assay, from the lowest: compound 2; then compounds 1 and 3 (each within the scatter of the next).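

This position is not indifferent in this assay: (tert-butoxycarbonyl)amino in place of hydroxy, on a saturated chain carbon, two bonds along the chain from an amide-type nitrogen, gives an 11-fold higher number from compound 2 to compound 3 (1.04 log units; beyond the scatter). Among these compounds, this is the first change that can be read in one place, and since a higher number stands for weaker inhibition, the exchange of hydroxy, with 1 heavy atom, for a group with 8 heavy atoms is a clear loss here rather than a tolerated change. The data on hand hold no independent measurement that could account for this step.

From the compounds shown here alone, a single step cannot separate the contribution of the amino nitrogen from that of the tert-butoxycarbonyl part, so it remains open whether a free amine, an acetylamino group or a carboxylic acid on this carbon would stay near the value of compound 2 at 1000 nM or fall with the value of compound 3 at 10900 nM. Going by these compounds, it is equally open whether the hydroxy group itself matters at this carbon, which a plain methyl group or a longer chain ending in hydroxy on the same core would test.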